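The source may report more compounds than this note shows. Statements on the series, on what has been measured and on what is new or still open speak of the compounds shown alone.

Measured compounds:
- compound 1 `Cc1cc(/C=C/c2ccc(O)cc2)[nH]n1`: 77400 nM
- compound 2 `COc1ccc(/C=C/c2cc(C)n[nH]2)cc1`: 12900 nM
- compound 3 `COc1ccc(/C=C/c2cc(C)no2)cc1`: 58300 nM

All three numbers come from an ADME assay on HEK293 cells (Homo sapiens) for cytotoxicity, read by MTT assay, with a stated time of 72 h; a lower number here means a stronger inhibitor, a higher number a weaker inhibitor. Compound 2 and compound 1 share a core and differ in one place, by hydrogen in place of methyl on an oxygen on an aromatic ring; in this assay the step is a 6.0-fold higher number from compound 2 to compound 1 (0.78 log units; beyond the scatter). Compound 3 carries a different core from compound 2; the difference between the two cores is not broken down here. In this assay compound 3 gives a number that stands within the scatter of compound 1, so no order between compound 3 and compound 1 is claimed, while compound 2 sits apart from both beyond the scatter.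

Compound 4 `Cc1cc(/C=C/c2ccc(O)cc2)on1` is not yet measured. It stands to compound 3 as compound 1 stands to compound 2: the change is hydrogen in place of methyl on an oxygen on an aromatic ring, made on the core of compound 3 rather than on the core of compound 2. On the core of compound 2 this change gave the step from compound 2 to compound 1 shown above, and that single observation is the only guide available; whether the same change carries over to the other core is not known from two examples. Taking the earlier step as the starting point, compound 4 is expected to show a step of a 3.4-fold higher number from compound 3 to compound 4 (0.54 log units; beyond the scatter) from compound 3, with wide uncertainty. The estimate for compound 4 in this assay is 200000 nM, with a range from 60000 nM to 600000 nM.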

Compound 4, half-maximal inhibitory concentration: 50200 nM
Compound 4: the middle estimate sits 4.0-fold (0.60 log units) above what was measured; measured number outside the range, below it.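

Carried to the core of compound 3, the change of methoxy to hydroxy gives a 1.2-fold lower number from compound 3 to compound 4 (0.06 log units; within the scatter) in this assay, so on this core it has no readable effect on the number. The same change therefore does not carry over from one core to the other in this pair, and a step seen on one of these cores cannot be used as a guide to the other: the same change on two cores in this assay, a 6.0-fold higher number (0.78 log units; beyond the scatter) from compound 2 to compound 1 and a 1.2-fold lower number (0.06 log units; within the scatter) from compound 3 to compound 4, 7.0-fold (0.84 log units) apart, beyond the scatter of two such steps. This rests on a single pair of steps, with one change and two cores in one cytotoxicity assay, so it shows that the outcome of this change differs between these two cores, but not which feature of the cores accounts for the difference, nor how the change would behave on any further core.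

The compounds shown leave open whether a longer chain such as ethyl in place of the methyl on that oxygen would also give different steps on the two cores. They also leave open whether an amine in place of the hydroxy group would follow the step seen on the core of compound 2, the one seen on the core of compound 3, or neither.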